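The compounds below may be only part of what the source reports. "The series", "measured", "known", "first", "only" and "open" are said of these compounds alone.

Measured so far:
compound 1, `O=C(Nc1ccc(Sc2nc3ccccc3s2)c(Cl)c1)c1ccccc1O` — 64000 nM
compound 2, `O=C(Nc1ccc(Sc2nc3ccccc3s2)cc1)c1ccccc1O` — 74000 nM
compound 3, `O=C(Nc1cccc(Cl)c1)c1ccccc1O` — 37000 nM

All three numbers come from an ADME assay on HEK293 cells (Homo sapiens) for cytotoxicity, read by reporter gene assay and resazurin assay, with a stated time of 48 h; a higher number here means that more compound is tolerated, a lower number that less compound is tolerated. Compound 2 gives the highest of the three numbers, but its neighbours sit close: compound 1 is a 1.2-fold higher number from compound 1 to compound 2 (0.06 log units; within the scatter) away, and compound 3, with its smaller core, lies furthest off at a gap that still stays within the scatter. So the three compounds are, in effect, tolerated alike.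

Compound 4, `COc1c(Br)cccc1C(=O)Nc1ccc(Sc2nc3ccccc3s2)cc1`, has not yet been measured in this assay. It differs from compound 2 in one place: a group of 9 heavy atoms (7 carbon, 1 oxygen, 1 bromine; one six-membered aromatic ring of carbon only) in place of a group of 7 heavy atoms (6 carbon, 1 oxygen; one six-membered aromatic ring of carbon only), on a carbonyl carbon

Among the measured compounds shown here, the only measured step, from compound 1 to compound 2, swaps hydrogen for chloro on the other aromatic ring and stays within the scatter; it says nothing direct about the change made here. For the measured compounds named here, no measured pair exchanges one benzoyl ring for another, so there is no step that bears on this change. The expectation therefore rests on compound 2 alone and is wide. Compound 4 is expected to give 60000 nM in this assay, within a range from 20000 nM to 150000 nM. That estimate means a step of a 1.2-fold lower number from compound 2 to compound 4 (0.09 log units; within the scatter), expected to be no change beyond the scatter.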

Compound 4, half-maximal cytotoxic concentration: > 100000 nM
Compound 4: a limit, no number; the forecaster's own chance of this, stated with the estimate: 20%; middle value at least 1.6-fold (0.22 log units) away from the limit.
By their numbers in this assay, from the lowest: compounds 3, 1 and 2 (each within the scatter of the next). At a limit, above all of these: compound 4.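

Among the compounds shown here, the earlier compounds only showed a swap of chloro for hydrogen on the other aromatic ring; compound 4 is the first to show a change on the carbonyl carbon, and the reading in this assay for compound 4 is a limit, not a number: the limit of > 100000 nM in this assay, at which 1 of the 4 values shown sits. For the compounds shown here, the step is an at least 1.3-fold higher number from compound 2 to compound 4 (0.13 log units; that floor lies within the scatter), so this place accepts a group of 9 heavy atoms that carries bromine, in place of 2-hydroxyphenyl, with no sign of less compound being tolerated, but the size of any rise cannot be read from this floor. The entering group also has no hydrogen-bond donor, so on this one pair the donor of 2-hydroxyphenyl is not needed to keep the tolerated concentration where it was.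

The compounds shown do not separate the bromine from the loss of the hydroxyl, as both change together in this single step. Also open, on these data alone, is how the tolerated concentration would respond to an amine or a carboxylic acid on this ring, and how far above the limit compound 4 truly lies.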